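The source may report more compounds than this note shows. Statements on the series, on what has been measured and on what is new or still open speak of the compounds shown alone.

In a functional assay on CCRF-CEM cells (Homo sapiens), read by MTT assay, with a stated time of 72 h (on this read-out higher numbers stand for weaker inhibition and lower numbers for stronger inhibition), compound 1 `CSc1ncnc2c1c(-c1ccsc1)cn2[C@@H]1O[C@H](CO)[C@@H](O)[C@H]1O` gives > 20000 nM, which is a limit and not a number. Compound 2 `Cc1ncnc2c1c(-c1cccs1)cn2[C@@H]1O[C@H](CO)[C@@H](O)[C@H]1O` gives > 20000 nM, again only a limit. Compound 3 `Cc1ncnc2c1c(-c1ccsc1)cn2[C@@H]1O[C@H](CO)[C@@H](O)[C@H]1O` is compound 2 with one group changed: thiophen-3-yl in place of thiophen-2-yl on an aromatic carbon. The same atoms are simply joined differently, so no change beyond the usual scatter is expected in this assay, in either direction. The estimated a number no higher from compound 2 to compound 3 (the limit leaves the size open) is therefore expected to be small. For compound 3 the expected value is 20000 nM, with an estimated range from 3000 nM to 40000 nM.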

Compound 3, half-maximal inhibitory concentration: 11200 nM
The estimate for compound 3 lay 1.8-fold (0.25 log units) above the measured number, within the range that was stated.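

In this assay, compound 3 is the only compound shown that gives a number and not a limit, so this position can now be read as a lower bound: thiophen-3-yl in place of thiophen-2-yl gives an at least 1.7-fold lower number from compound 2 to compound 3 (0.25 log units; that floor lies within the scatter), and methyl in place of methylsulfanyl gives an at least 1.7-fold lower number from compound 1 to compound 3 (0.25 log units; that floor lies within the scatter). Neither floor shows a real change, because each step starts from a limit: the limit of > 20000 nM in this assay, at which 2 of the 3 values shown sit.

As far as these compounds go, the true size of both steps stays open. So does the effect of an amine or a longer chain in place of the methyl on the shared core.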